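This account rests on a few compounds, and the source may have more. Where it says the series, first, only, none or still open, it means among the compounds named here.

Measured compounds:
Compound 1, `O=C1CCC(=O)N1C[C@H]1CN(c2ccc(-n3cc(-c4ccccn4)cn3)c(F)c2)C(=O)O1`: in an ADME assay on L02 cells (Homo sapiens) for cytotoxicity, read by MTT assay, with a stated time of 48 h (a lower number here means a stronger inhibitor, a higher number a weaker inhibitor), compound 1 gives > 400 ug/mL, which is a limit of the assay.
Compound 2, `O=C(OC[C@H]1CN(c2ccc(-n3cc(-c4ccccn4)cn3)c(F)c2)C(=O)O1)c1ccccc1`: in this assay compound 2 gives > 400 ug/mL, likewise a limit.
Compound 3, `O=C1O[C@@H](CNC(=O)C(F)(F)F)CN1c1ccc(-n2cc(-c3ccccn3)cn2)c(F)c1`: in this assay compound 3 gives > 400 ug/mL, again a limit.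

Compound 3 thus stands at the upper edge of what this assay can report, and it shares this position with both other measured compounds (the limit of > 400 ug/mL in this assay, at which 3 of the 3 values shown sit). The steps among the measured compounds are a step that the two limits leave unreadable from compound 1 to compound 2, a step that the two limits leave unreadable from compound 1 to compound 3 and a step that the two limits leave unreadable from compound 2 to compound 3; each runs between two limits, so no size can be read from any of them.

Compound 4, `CONC(=O)[C@H]1CN(c2ccc(-n3cc(-c4ccccn4)cn3)c(F)c2)C(=O)O1`, has not yet been measured in this assay. It differs from compound 3 by methoxycarbamoyl in place of (((trifluoromethyl)carbonyl)amino)methyl on a saturated ring carbon. Going by the values given here, no measured step covers this change, and the three steps that do exist give no size at all. The expectation for compound 4 therefore rests only on the observation that every measured value in this assay sits at the limit (the limit of > 400 ug/mL in this assay, at which 3 of the 3 values shown sit). The step from compound 3 to compound 4 is expected to be a number no higher from compound 3 to compound 4 (the limit leaves the size open). Compound 4 is accordingly estimated at 400 ug/mL, within 150 ug/mL to 800 ug/mL, and is expected most likely to be reported once more only as a limit.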

Compound 4, half-maximal inhibitory concentration: > 400 ug/mL
Compound 4 was reported as a limit (the forecaster's own chance of this, stated with the estimate: 85%); the middle value sits exactly at the limit.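

Compound 4, like compound 1, compound 2 and compound 3, is reported only as a limit, so none of the steps linking compound 4 to the other three can be read: the limit of > 400 ug/mL in this assay, at which 4 of the 4 values shown sit.

The compounds shown leave open how the groups on the saturated ring carbon compare in this assay and whether any of them would give a value inside the range of the assay.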